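The source may report more compounds than this note shows. Statements on the series, on what has been measured and on what is new or still open speak of the compounds shown alone.

Measured compounds:
Compound 1, `CCOC(=O)[C@@H]1CCCN(S(=O)(=O)c2ccc(S(=O)(=O)N(CC)CC)nc2)C1`, gives in a functional assay on MIA PaCa-2 cells (Homo sapiens) for inhibition, read by MTT assay, with a stated time of 3 days (a lower number here means a stronger inhibitor, a higher number a weaker inhibitor), a limit rather than a number: > 10000 nM.
Compound 2, `CCOC(=O)[C@@H]1CCCN(S(=O)(=O)c2ccc(S(=O)(=O)N3CCCCC3)cc2)C1`, sits at a limit of this assay: > 10000 nM.
Compound 3, `CCOC(=O)[C@@H]1C[C@@H](O)CN(S(=O)(=O)c2ccc(S(=O)(=O)N(CC)CC)cc2)C1`, also sits at a limit of this assay: > 10000 nM.

Within the data shown here, all three measured compounds stand at the same place in this assay, (the limit of > 10000 nM in this assay, at which 3 of the 3 values shown sit), so no step between any two of them can be read as a number, and compound 2 stands exactly where the other two do, at a limit and not a value. Nothing in these three measurements sets one compound apart from another.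

The compound not yet measured is compound 4, `CCOC(=O)[C@@H]1CCCN(S(=O)(=O)c2ccc(S(=O)(=O)N3CCOCC3)cc2)C1`. It comes from compound 2 through one change, (morpholin-4-yl in place of piperidin-1-yl on a sulfonyl sulfur). Among the measured compounds shown here, since every measured value is a limit, there is no measured step here on which to rest a size or direction; the change in compound 4 is a modest exchange of one saturated six-membered ring for another, and the three compounds that share its core give no sign of inhibition at the limit.

Compound 4 is therefore expected to stay at or near the same limit, and the step that the limit leaves unreadable from compound 2 to compound 4 is estimated as none beyond the scatter. The estimate for compound 4 in this assay is 20000 nM, with a range from 5000 nM to 80000 nM.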

Compound 4, half-maximal inhibitory concentration: > 10000 nM
Compound 4 gave a limit, no number; the forecaster's own chance of this, stated with the estimate: 85%; the middle value lies beyond the limit too.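

Among these compounds, compound 4, like compound 2, gives only a limit in this assay, so the exchange of piperidin-1-yl for morpholin-4-yl yields no step that can be read: the limit of > 10000 nM in this assay, at which 4 of the 4 values shown sit. The compounds shown leave open how strongly any of them inhibits, and whether any change to the shared core would give a measurable value.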